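Changing the Side Chain of Compound 2

The source may hold more compounds than are shown below. What is called first, only, known or untested is meant among the compounds shown, and "the series" means these compounds.

In a functional assay on A-375 cells (Homo sapiens) for antiproliferative activity, read by MTT assay, with a stated time of 24 h (a lower number here means a stronger inhibitor, a higher number a weaker inhibitor), compound 1 `C=CCOc1ccc2c(=O)c(-c3cc(OC)c(OC)cc3OC)coc2c1` gives 4750 nM. Compound 2 `COc1cc(OC)c(-c2coc3cc(OCc4ccccc4)ccc3c2=O)cc1OC` gives 1640 nM, the lower of the two numbers. Compound 3 `COc1cc(OC)c(-c2coc3cc(OCC(=O)c4cccc(C(F)(F)F)c4)ccc3c2=O)cc1OC` is not yet measured, and its change is (3-(trifluoromethyl)phenyl)carbonyl in place of phenyl on a saturated chain carbon bound to an oxygen on an aromatic ring. Going by the values given here, only one measured step bears on this swap at the same chain carbon: a 2.9-fold lower number from compound 1 to compound 2 (0.46 log units; beyond the scatter), which is modest. One step gives weak guidance for a much larger group, so in this assay only a small further drop is expected, a 1.4-fold lower number from compound 2 to compound 3 (0.14 log units; within the scatter). For compound 3, the estimated value is 1200 nM, with an expected range from 350 nM to 4000 nM.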

Compound 3, half-maximal inhibitory concentration: > 10000 nM
Compound 3 ended at the assay's limit (the forecaster's own chance of this, stated with the estimate: 5%); middle value at least 8.3-fold (0.92 log units) away from the limit.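

Compound 3 sits at the assay's limit in this assay: the limit of > 10000 nM in this assay, at which 1 of the 3 values shown sits.

This chain carbon therefore does not accept every larger group: the swap gives an at least 6.0-fold higher number from compound 2 to compound 3 (0.78 log units; beyond the scatter), against the earlier gain of a 2.9-fold lower number from compound 1 to compound 2 (0.46 log units; beyond the scatter). The new group also falls behind vinyl, with an at least 2.1-fold higher number from compound 1 to compound 3 (0.32 log units; beyond the scatter).

The carbonyl and the trifluoromethyl enter together, and the compounds shown cannot separate them. Still open, as far as these compounds go, is how a plain phenylcarbonyl, a 3-(trifluoromethyl)phenyl without the carbonyl, or an amine at this chain carbon would behave.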